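The compounds below may be only part of what the source reports. "The series", "measured", "known", "first", "only" and "open" are said of these compounds alone.

Measured compounds:
compound 1, `COc1nc(N)nc2c1c(-c1ccsc1)cn2[C@@H]1O[C@H](CO)[C@@H](O)[C@H]1O`: > 20000 nM
compound 2, `COc1nc(N)nc2c1c(-c1cccs1)cn2[C@@H]1O[C@H](CO)[C@@H](O)[C@H]1O`: > 20000 nM
compound 3, `CNc1ncnc2c1c(-c1cccs1)cn2[C@@H]1O[C@H](CO)[C@@H](O)[C@H]1O`: > 20000 nM

All three were tested in a functional assay on CEM-DNR-bulk cells (Homo sapiens), read by MTT assay, with a stated time of 72 h; a higher number here means a weaker inhibitor, a lower number a stronger inhibitor. In this assay compound 2 gives > 20000 nM, which is a limit of the assay and not a number. Compound 1 differs from compound 2 by thiophen-3-yl in place of thiophen-2-yl on an aromatic carbon. In this assay compound 1 gives > 20000 nM, again a limit. The step that the two limits leave unreadable from compound 2 to compound 1 therefore cannot be read from these two results. Compound 3 carries a different core from compound 2; how the two cores differ is not broken down here. In this assay compound 3 gives > 20000 nM, also a limit. What unites the three is the limit of > 20000 nM in this assay, at which 3 of the 3 values shown sit.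

Compound 4, `CNc1ncnc2c1c(-c1ccsc1)cn2[C@@H]1O[C@H](CO)[C@@H](O)[C@H]1O`, has not yet been measured. Among the compounds with values here, it differs from compound 3 by thiophen-3-yl in place of thiophen-2-yl on an aromatic carbon, the same change as the one behind a step that the two limits leave unreadable from compound 2 to compound 1, made at the same place. The step that the limit leaves unreadable from compound 3 to compound 4 in this assay is expected to be small or unreadable, because the limit of > 20000 nM in this assay, at which 3 of the 3 values shown sit, and the matching change gave no readable movement. Compound 4 is therefore estimated at 30000 nM in this assay, with a likely range from 15000 nM to 80000 nM, and it is expected that the assay will most likely report only a limit once more.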

Compound 4, half-maximal inhibitory concentration: > 20000 nM
Compound 4 was reported as a limit (the forecaster's own chance of this, stated with the estimate: 85%); the middle value does not contradict the limit.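

In this assay compound 4 gives > 20000 nM, which is a limit of the assay and not a number. No step can be read between compound 3 and compound 4, nor between any other compounds shown: the limit of > 20000 nM in this assay, at which 4 of the 4 values shown sit.

How strongly any of these compounds acts, and whether thiophen-3-yl and thiophen-2-yl differ at all in this cell assay, remains open.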